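A few compounds are considered here, and "the series" means these few. Any claim that something is new, unique, unknown or untested is made for them only; others in the source may bear on it.

Measured in a functional assay on KYSE-450 cells (Homo sapiens) for inhibition, read by MTT assay, with a stated time of 48 h; a lower number here means a stronger inhibitor, a higher number a weaker inhibitor:
Compound 1 `COc1ccc(CN(C(=O)C(C)Br)c2cc(OC)c(OC)c(OC)c2)cc1O`: 160 nM
Compound 2 `COc1ccc(CN(C(=O)/C=C/CBr)c2cc(OC)c(OC)c(OC)c2)cc1O`: 100 nM

Among the compounds with values here, only these two compounds have been measured, and they cannot be told apart: the single step between them is a 1.6-fold lower number from compound 1 to compound 2 (0.20 log units; within the scatter). Compound 2, at 100 nM, therefore stands level with compound 1 in this assay.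

Compound 3 `COc1ccc(CN(C(=O)C2CC2)c2cc(OC)c(OC)c(OC)c2)cc1O` has not yet been measured. It carries cyclopropyl in place of 3-bromoprop-1-en-1-yl on a carbonyl carbon. Within the data shown here, the one measured step bears on this change only in part, as it exchanged one bromine-bearing group on the same carbonyl carbon for another. Going by these compounds, neither measured compound lacks bromine, so the effect of losing it is unknown, and a wide range is warranted. With that caution, a modest move towards a higher number is expected in this assay, although a result within the scatter would be no surprise.

The expected change is a 2.8-fold higher number from compound 2 to compound 3 (0.45 log units; beyond the scatter).

For compound 3 the estimate is 280 nM, with an expected range from 80 nM to 1200 nM.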

Compound 3, half-maximal inhibitory concentration: 80 nM
Estimate against measurement, compound 3: 3.5-fold (0.54 log units) above; the range from low to high includes it.
By their numbers in this assay, from the lowest: compounds 3, 2 and 1 (each within the scatter of the next).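

In this assay, cyclopropyl in place of 3-bromoprop-1-en-1-yl on a carbonyl carbon gives a 1.3-fold lower number from compound 2 to compound 3 (0.10 log units; within the scatter), and cyclopropyl in place of 1-bromoethyl gives a 2.0-fold lower number from compound 1 to compound 3 (0.30 log units; within the scatter), so all three compounds stand level. Within the data shown here, the earlier pair could compare only one bromine-bearing group with another, whereas compound 3 carries no bromine, and its group on the carbonyl carbon is a three-membered ring of carbon only, without a double bond outside aromatic rings. Among these three compounds, then, neither bromine nor an open chain on the carbonyl carbon is needed for a number at this level, but no measurement available here explains why the three groups give results that cannot be told apart.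

The compounds shown leave open how far this insensitivity extends, as all three groups on the carbonyl carbon are small and carry no hydrogen-bond donors or acceptors. An amine, a carboxylic acid or a longer carbon chain at the same place could show whether the number in this assay stays level or moves beyond the scatter.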